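From oxan-4-yl to 1-(oxan-4-yl)ethyl on a shared core

A few compounds are considered here, and "the series" means these few. Any claim that something is new, unique, unknown or untested is made for them only; others in the source may bear on it.

In a physicochemical assay for lipophilicity, at pH 7.4 (on this read-out lower numbers stand for lower lipophilicity and higher numbers for higher lipophilicity), compound 1 `CCc1ccc(N(CC(C)C)S(=O)(=O)c2ccc3c(c2)C(O)CC(C2CCN(S(C)(=O)=O)CC2)O3)cc1` reads 3.22 and compound 2 `CCc1ccc(N(CC(C)C)S(=O)(=O)c2ccc3c(c2)C(O)CC(C2CCOCC2)O3)cc1` reads 4.12 while compound 3 `CCc1ccc(N(CC(C)C)S(=O)(=O)c2ccc3c(c2)CCC(C2CCOCC2)O3)cc1` reads 5.38 on the same scale. Compound 2 therefore stands in the middle of the three, with compound 1 lowest and compound 3 highest.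

Compound 4 `CCc1ccc(N(CC(C)C)S(=O)(=O)c2ccc3c(c2)C(O)CC(C(C)C2CCOCC2)O3)cc1` has not yet been measured. The change 1-(oxan-4-yl)ethyl in place of oxan-4-yl on a saturated ring carbon puts 1-(oxan-4-yl)ethyl in place of oxan-4-yl on a saturated ring carbon next to the ring oxygen.

Going by the values given here, two measured steps bear on this change. At that same carbon, oxan-4-yl in place of 1-(methylsulfonyl)piperidin-4-yl gave a number 0.90 log units higher from compound 1 to compound 2 (beyond the scatter) as a modest step. At the ring atom that bears a hydroxy group, hydrogen in place of hydroxy gave a number 1.26 log units higher from compound 2 to compound 3 (beyond the scatter) as a large step. Neither step matches the present swap, in which the entering group differs from the leaving one by carbon alone, so the size remains a judgement. The expected change is a number 0.58 log units higher from compound 2 to compound 4 (beyond the scatter) as a modest upward step on this scale. For compound 4 the estimated value is 4.7 with an expected range from 4.3 to 5.1 on the same scale.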

Compound 4, distribution coefficient: 5.04
Estimate against measurement, compound 4: 0.34 log units below; measured number inside the range.
By their numbers in this assay, from the lowest: compound 1; then compound 2; then compound 4; then compound 3.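

In this assay the earlier compounds had shown this saturated ring carbon next to the ring oxygen only under an exchange of one ring group for another, whereas 1-(oxan-4-yl)ethyl in place of oxan-4-yl keeps the ring and its hetero atom and adds carbon alone, and it still gives a number 0.92 log units higher from compound 2 to compound 4 (beyond the scatter) as its result. That modest step is close in size to the one seen earlier, a number 0.90 log units higher from compound 1 to compound 2 (beyond the scatter) in that case, so the added carbon alone moves the number about as far as the full exchange of 1-(methylsulfonyl)piperidin-4-yl for oxan-4-yl did. Taken together, the replacement of 1-(methylsulfonyl)piperidin-4-yl by 1-(oxan-4-yl)ethyl amounts to a number 1.82 log units higher from compound 1 to compound 4 (beyond the scatter) and is a large step at this one position, and nothing given here accounts for the cause of these shifts.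

The compounds shown leave open whether 1-(oxan-4-yl)ethyl would give a step of similar size on the core of compound 3, where hydrogen stands in place of hydroxy. They also leave open how a longer chain or an amine at this same carbon would read on this scale.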